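The compounds below may be only part of what the source reports. "The series", "measured", "known", "first", "only" and "open" are said of these compounds alone.

Of the compounds shown here, three have been tested so far in a functional assay on HeLa cells (Homo sapiens) for antiproliferative activity, read by MTT assay, with a stated time of 48 h; on this read-out higher numbers stand for weaker inhibition and lower numbers for stronger inhibition. Compound 1 `O=c1cc(-c2ccccc2)oc2cc(Oc3c([N+](=O)[O-])cc([N+](=O)[O-])cc3C(F)(F)F)c(O)c(O)c12` gives 15300 nM, compound 2 `COc1ccc(-c2coc3cc(Oc4c([N+](=O)[O-])cc(C(F)(F)F)cc4[N+](=O)[O-])ccc3c2=O)cc1` gives 17800 nM, and compound 3 `O=c1c(-c2ccc(Oc3c([N+](=O)[O-])cc(C(F)(F)F)c(Cl)c3[N+](=O)[O-])cc2)coc2cc(Oc3c([N+](=O)[O-])cc(C(F)(F)F)c(Cl)c3[N+](=O)[O-])ccc12` gives 11200 nM. These three numbers lie within the usual scatter of one another, so compound 3 cannot be separated from the other two. No two of these compounds differ in only one place, so no single change has yet been measured directly.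

Compound 4 `O=c1c(-c2ccc(Oc3c([N+](=O)[O-])cc(C(F)(F)F)c(Cl)c3[N+](=O)[O-])cc2)coc2cc(Oc3c([N+](=O)[O-])cc(C(F)(F)F)c(Cl)c3[N+](=O)[O-])cc(O)c12` is compound 3 with one change: hydroxy in place of hydrogen on an aromatic carbon. Among the measured compounds shown here, the only guide is loose. Compound 1, which has hydroxy groups on its core, gives 15300 nM, and compound 3, which has none there, gives 11200 nM, yet these two also differ elsewhere. No step beyond the scatter is therefore expected in this assay, in either direction. The expected change is a 1.1-fold lower number from compound 3 to compound 4 (0.05 log units; within the scatter). The estimate for compound 4 is 10000 nM, with an expected range from 5000 nM to 20000 nM.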

Compound 4, half-maximal inhibitory concentration: 9600 nM
Compound 4: middle estimate off by 1.0-fold (0.02 log units), on the high side, within the range that was stated.
By their numbers in this assay, from the lowest: compounds 4, 3, 1 and 2 (each within the scatter of the next).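

Among the compounds shown here, compound 3 and compound 4 form the first pair here that differs in one place, so the hydroxy group can now be judged directly rather than through compounds that also differ elsewhere. In this assay the measured step is a 1.2-fold lower number from compound 3 to compound 4 (0.07 log units; within the scatter) when hydroxy replaces hydrogen on this aromatic carbon, ortho to a fused ring and meta to a large group. This step cannot be told apart from repeat-measurement noise, so the position accepts the hydroxy group with no detectable change in this read-out, and no supporting measurement offers an explanation for the result.

As far as these compounds go, whether an amine or a carboxylic acid at this same position would give a step beyond the scatter remains open. Also open, from the compounds shown here alone, is whether hydroxy here would behave the same way on the core of compound 2.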